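Working notes: dimethylamino to hydroxymethyl on the aryl ring

This account rests on a few compounds, and the source may have more. Where it says the series, first, only, none or still open, it means among the compounds named here.

Measured so far in an ADME assay on BJ cells (Homo sapiens) for cytotoxicity, read by luminescence, with a stated time of 72 h (on this read-out lower numbers stand for an effect already at smaller amounts and higher numbers for an effect only at larger amounts of compound), each value a limit:
compound 1 `CCOC(=O)c1c(-c2ccccc2)[nH]c2cc(OC)ccc2c1=O`: > 21500 nM
compound 2 `CCOC(=O)c1c(-c2cccc(OC)c2)[nH]c2cc(OC)ccc2c1=O`: > 21500 nM
compound 3 `CCOC(=O)c1c(-c2cccc(N(C)C)c2)[nH]c2cc(OC)ccc2c1=O`: > 21500 nM

In this assay compound 3 gives > 21500 nM, which is a limit and not a number. Compounds 1 and 2 offer no number to rank it against, as all three stand at the limit of > 21500 nM in this assay, at which 3 of the 3 values shown sit.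

Compound 4 `CCOC(=O)c1c(-c2cccc(CO)c2)[nH]c2cc(OC)ccc2c1=O` carries hydroxymethyl in place of dimethylamino on an aromatic carbon, meta to a large group, and the rest of the structure is unchanged: hydroxymethyl in place of dimethylamino on an aromatic carbon.

The closest measured change is a step that the two limits leave unreadable from compound 2 to compound 3. The other two changes on this ring are a step that the two limits leave unreadable from compound 1 to compound 2 and a step that the two limits leave unreadable from compound 1 to compound 3. None of the three has a readable size, so they support neither a direction nor a magnitude. No step beyond the scatter is therefore expected in this assay, and another limit is the most likely report given (the limit of > 21500 nM in this assay, at which 3 of the 3 values shown sit). The step estimated on this basis is a step that the limit leaves unreadable from compound 3 to compound 4. For compound 4 the estimated value is 30000 nM, with an expected range from 15000 nM to 60000 nM.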

Compound 4, half-maximal effective concentration: > 21500 nM
Compound 4: a limit, no number (the forecaster's own chance of this, stated with the estimate: 85%); the middle value does not contradict the limit.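

In this assay compound 4 gives > 21500 nM, which is a limit and not a number. The steps linking compound 4 to compounds 1, 2 and 3 cannot be read, because all four compounds stand at the same limit: the limit of > 21500 nM in this assay, at which 4 of the 4 values shown sit.

The compounds shown leave open whether any of these aryl changes has an effect in this assay, and in which direction or of what size.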